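The compounds below may be only part of what the source reports. "The series", "measured", "known", "first", "only" and "open" are said of these compounds alone.

Measured compounds:
Compound 1, `O=C(/C=C/c1ccc2c(c1)B(O)OC2)c1ccc(I)cc1`: in a toxicity assay on MCF-10A cells (Homo sapiens) for cytotoxicity, read by MTT assay, with a stated time of 48 h (on this read-out lower numbers stand for stronger inhibition and higher numbers for weaker inhibition), compound 1 gives > 100000 nM.
Compound 2, `CSc1ccc(C(=O)/C=C/c2ccc3c(c2)B(O)OC3)cc1`: in this assay compound 2 gives 7400 nM.

The value of compound 1 is a limit of the assay and not a number (the limit of > 100000 nM in this assay, at which 1 of the 2 values shown sits), so compound 1 stands at the weak end of what has been measured so far. For the measured compounds named here, the single measured step replaces one group with another: with methylsulfanyl in place of iodo on an aromatic carbon, an at least 13-fold lower number from compound 1 to compound 2 (1.13 log units; beyond the scatter).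

Compound 3, `Nc1cccc(C(=O)/C=C/c2ccc3c(c2)B(O)OC3)c1`, has not yet been measured. It differs from compound 1 by 3-aminophenyl in place of 4-iodophenyl on a carbonyl carbon. This is a different change from the measured one, so the measured step bears on it only loosely. Going by the values given here, still, the one exchange of the iodo-bearing group seen so far gave a lower number (an at least 13-fold lower number from compound 1 to compound 2 (1.13 log units; beyond the scatter)), and a lower number, of uncertain size, is therefore expected for compound 3, with a fair chance that only a limit is reported again.

Compound 3 is expected to give about 35000 nM in this assay, between 6000 nM and 100000 nM. That estimate would mean a step of an at least 2.8-fold lower number from compound 1 to compound 3 (0.45 log units; beyond the scatter).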

Compound 3, half-maximal inhibitory concentration: 19600 nM
Compound 3: middle estimate off by 1.8-fold (0.25 log units), on the high side, and the stated range covers the measured number.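

In this assay, a second replacement of the 4-iodophenyl group on the carbonyl carbon also lowers the number, with 3-aminophenyl in its place: an at least 5.1-fold lower number from compound 1 to compound 3 (0.70 log units; beyond the scatter). The lower number on leaving 4-iodophenyl is therefore not tied to methylsulfanyl, since it also appears with a quite different group at the same place on the shared core, and both replacements give a step beyond the scatter. The value of compound 1 is a limit and not a number, so the real size of this step stays unknown: the limit of > 100000 nM in this assay, at which 1 of the 3 values shown sits.

This single exchange removes the iodo group, adds an amino group and changes the position named on the ring, and the compounds shown cannot tell which of these matters for the number. On these data alone, how an unsubstituted phenyl, a 4-aminophenyl or a 3-iodophenyl group would read at this carbonyl carbon remains open, and so does whether a carboxylic acid on the same ring would move the number in the same direction.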